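Replacing the 3,4-dihydroxyphenyl group of compound 3

A few compounds are considered here, and "the series" means these few. Any claim that something is new, unique, unknown or untested is made for them only; others in the source may bear on it.

Measured in a functional assay on MCF7 cells (Homo sapiens) for antiproliferative activity, read by MTT assay, with stated times of 24 h and 72 h; on this read-out lower numbers stand for stronger inhibition and higher numbers for weaker inhibition:
compound 1 (`COc1ccc([C@@H]2[C@H](Oc3ccccc3)C(=O)N2c2cc(OC)c(OC)c(OC)c2)cc1`) gives 35000 nM
compound 2 (`COc1cc(N2C(=O)[C@@H](Oc3ccccc3)[C@H]2c2ccc(N=[N+]=[N-])cc2)cc(OC)c1OC`) gives 23000 nM
compound 3 (`COc1cc(N2C(=O)[C@@H](Oc3ccccc3)[C@H]2c2ccc(O)c(O)c2)cc(OC)c1OC`) gives 4500 nM

Compound 3 stands lowest of the three in this assay at 4500 nM and lies beyond the scatter from both of the others. Compound 4 (`COc1cc([N+](=O)[O-])c([C@@H]2[C@H](Oc3ccccc3)C(=O)N2c2cc(OC)c(OC)c(OC)c2)cc1O`) has not yet been measured. The change from compound 3 is a group of 12 heavy atoms (7 carbon, 1 nitrogen, 4 oxygen; one six-membered aromatic ring of carbon only) in place of a group of 8 heavy atoms (6 carbon, 2 oxygen; one six-membered aromatic ring of carbon only), on a saturated ring carbon and it falls on a saturated ring carbon of the four-membered ring of the shared core.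

For the measured compounds named here, three measured steps bear on this place: a 7.8-fold lower number from compound 1 to compound 3 (0.89 log units; beyond the scatter) and a 5.1-fold lower number from compound 2 to compound 3 (0.71 log units; beyond the scatter) are both modest and beyond the scatter, whereas a 1.5-fold lower number from compound 1 to compound 2 (0.18 log units; within the scatter) stays within it. Neither measured compound lacking the 3,4-dihydroxyphenyl group reaches the number of compound 3, with compound 1 at 35000 nM and compound 2 at 23000 nM in this comparison. Going by the values given here, the group entering in compound 4 appears in no measured compound, so this guide is a loose one. A modest move towards a higher number is therefore expected, and the expected change is a 2.9-fold higher number from compound 3 to compound 4 (0.46 log units; beyond the scatter) on this estimate. Compound 4 is estimated at 13000 nM with 3500 nM to 40000 nM as the expected range.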

Compound 4, half-maximal inhibitory concentration: 59000 nM
Estimate against measurement, compound 4: 4.5-fold (0.66 log units) below; the whole stated range lies below it.
By their numbers in this assay, from the lowest: compound 3; then compounds 2, 1 and 4 (each within the scatter of the next, the first and the last beyond it).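

For the compounds shown here, at this saturated ring carbon of the four-membered ring, this assay gives a 13-fold higher number from compound 3 to compound 4 (1.12 log units; beyond the scatter) as the largest step among the four compounds, so exchanging the aryl group here can cost more than the earlier comparisons showed. The hydroxy group kept in the entering group, alongside its methoxy and nitro groups, does not preserve the standing of compound 3, which remains lowest of the four and beyond the scatter from each of the others. The other two comparisons separate compound 4 from the azide-bearing compound 2, with a 2.6-fold higher number from compound 2 to compound 4 (0.41 log units; beyond the scatter) lying beyond the scatter, but not from the methoxy-bearing compound 1, with a 1.7-fold higher number from compound 1 to compound 4 (0.23 log units; within the scatter) staying within it, so a second route to a weak number is not distinguished from the first. Nothing available here accounts for these differences.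

Several features change together between compound 3 and compound 4, so the share of the nitro group, the methoxy group and the lost hydroxy group remains unresolved. Also open, from the compounds shown here alone, is how this position would respond to an amine or a carboxylic acid in place of the nitro group on the same aromatic ring.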